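The source may hold more compounds than are shown below. What is called first, only, known or untested is meant among the compounds shown, and "the series" means these compounds.

Working notes on the chain series. In a functional assay on SW480 cells (Homo sapiens) for antiproliferative activity, read by MTT assay, with a stated time of 48 h (a higher number here means a weaker inhibitor, a lower number a stronger inhibitor), compound 1 `CCCCCCC(CCO)n1cnc2c(OC)ncnc21` gives > 50000 nM, which is a limit of the assay and not a number. Compound 2 `CCCCCCCC(CCO)n1cnc2c(OC)ncnc21` gives 23900 nM. Compound 3 `CCCCCCCCC(CCO)n1cnc2c(OC)ncnc21` gives 24600 nM, so compound 3 cannot be separated from compound 2 in this assay. Compound 4 `CCCCCCCCCC(CCO)n1cnc2c(OC)ncnc21` departs from compound 3 as follows: methyl in place of hydrogen on a saturated chain carbon, nine bonds along the chain from an aromatic nitrogen.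

Two measured steps of the same kind bear on this one. The earlier, an at least 2.0-fold lower number from compound 1 to compound 2 (0.32 log units; beyond the scatter), rests on a limit and gives only a floor for its size. Among the compounds with values here, the nearer, a 1.0-fold higher number from compound 2 to compound 3 (0.01 log units; within the scatter), is the better guide, being the only one between two true numbers. On that evidence, no step beyond the scatter is expected in this assay. The expected step is a 1.2-fold lower number from compound 3 to compound 4 (0.07 log units; within the scatter). For compound 4 the estimated value is 21000 nM, with an expected range of 9500 nM to 46000 nM.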

Compound 4, half-maximal inhibitory concentration: 3250 nM
Estimate against measurement, compound 4: 6.5-fold (0.81 log units) above, outside the stated range (below it).
By their numbers in this assay, from the lowest: compound 4; then compounds 2 and 3 (each within the scatter of the next). At a limit, above all of these: compound 1.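

In this assay, within the data shown here, methyl in place of hydrogen on a saturated chain carbon, nine bonds along the chain from an aromatic nitrogen, gives the first step between two true numbers that lies beyond the scatter: a 7.6-fold lower number from compound 3 to compound 4 (0.88 log units; beyond the scatter). The same kind of change at eight bonds along the chain gave a 1.0-fold higher number from compound 2 to compound 3 (0.01 log units; within the scatter), so the response to chain length is uneven across these compounds, and the ethyl comparison shows the same gain: a 7.4-fold lower number from compound 2 to compound 4 (0.87 log units; beyond the scatter). Compound 1 gives > 50000 nM, which is a limit of the assay and not a number, so an at least 15-fold lower number from compound 1 to compound 4 (1.18 log units; beyond the scatter) is only a floor.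

On these data alone, whether a longer chain lowers the number further or reverses the gain remains open. Also open, as far as these compounds go, is whether an amine or a carboxylic acid in place of the hydroxyl would keep it.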